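The compounds below may be only part of what the source reports. "The series", "measured", "known", "first", "only" and "open" are said of these compounds alone.

Measured in a functional assay on HT-29 cells (Homo sapiens) for inhibition, read by CCK-8 assay, with a stated time of 24 h; on this read-out higher numbers stand for weaker inhibition and lower numbers for stronger inhibition:
- compound 1 `O=C1Nc2ccccc2/C1=C/c1ccc(-c2cn(-c3ccccc3F)nn2)cc1`: 10500 nM
- compound 2 `O=C1Nc2ccccc2/C1=C/c1ccc(-c2cn(-c3ccccc3Cl)nn2)cc1`: > 20000 nM (a limit)
- compound 3 `O=C1Nc2ccccc2/C1=C/c1ccc(-c2cn(-c3ccc(Cl)cc3)nn2)cc1`: 14000 nM

Compound 2 has only a limit and no number: the limit of > 20000 nM in this assay, at which 1 of the 3 values shown sits. Compound 4 `N#Cc1cccc(-n2cc(-c3ccc(/C=C4\C(=O)Nc5ccccc54)cc3)nn2)c1` carries 3-cyanophenyl in place of 2-chlorophenyl on an aromatic nitrogen of the five-membered aromatic ring with 3 nitrogen: 3-cyanophenyl in place of 2-chlorophenyl on an aromatic nitrogen.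

Three measured steps change the group on that nitrogen or its halogen: an at least 1.9-fold higher number from compound 1 to compound 2 (0.27 log units; that floor lies within the scatter), an at least 1.4-fold lower number from compound 2 to compound 3 (0.15 log units; that floor lies within the scatter) and a 1.3-fold higher number from compound 1 to compound 3 (0.12 log units; within the scatter). Among the compounds with values here, all three stay within the scatter, and 3-cyanophenyl appears in no measured compound. In this assay the expected change is therefore none beyond the scatter, at most a slightly lower number: an at least 1.3-fold lower number from compound 2 to compound 4 (0.12 log units; that floor lies within the scatter). For compound 4 the estimated value is 15000 nM, with an expected range of 7000 nM to 30000 nM.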

Compound 4, half-maximal inhibitory concentration: > 20000 nM
Compound 4 gave a limit, no number (the forecaster's own chance of this, stated with the estimate: 30%); middle value at least 1.3-fold (0.12 log units) from the limit.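

In this assay compound 4 is a limit and not a number, as compound 2 is, and the step between them cannot be read: the limit of > 20000 nM in this assay, at which 2 of the 4 values shown sit. With 3-cyanophenyl on the aromatic nitrogen, the readable steps are an at least 1.4-fold higher number from compound 3 to compound 4 (0.15 log units; that floor lies within the scatter) and an at least 1.9-fold higher number from compound 1 to compound 4 (0.27 log units; that floor lies within the scatter). A ring without halogen thus shows no sign of a lower number, though both floors lie within the scatter.

Going by these compounds, whether an amine or a carboxylic acid on that phenyl ring would give a clearly lower number stays open. On these data alone, the true values of compound 2 and compound 4 also stay open.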